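Replacing one aryl group by another in a cytotoxicity series

The source may hold more compounds than are shown below. What is called first, only, known or untested is meant among the compounds shown, and "the series" means these compounds.

Among the compounds with values here, compound 2 `CN(C)CCn1cnnc1-c1cc(Oc2ccc(NC(=O)N/N=C/c3c(O)ccc4ccccc34)cc2F)ccn1` gives 890 nM in a functional assay on NCI-H460 cells (Homo sapiens) for cytotoxicity, read by MTT assay, with a stated time of 72 h (a higher number here means a weaker inhibitor, a lower number a stronger inhibitor), the lowest of the two numbers so far; compound 1 `COc1cc(/C=N/NC(=O)Nc2ccc(Oc3ccnc(-c4nncn4CCN(C)C)c3)c(F)c2)cc(OC)c1OC` gives 2770 nM there. Within the data shown here, the single measured step, a 3.1-fold lower number from compound 1 to compound 2 (0.49 log units; beyond the scatter), is an exchange of one aryl group for another at the same position. Compound 3 `CN(C)CCn1cnnc1-c1cc(Oc2ccc(NC(=O)N/N=C/c3cccc(Br)c3)cc2F)ccn1` carries the change (3-bromophenyl in place of 2-hydroxynaphthalen-1-yl on a carbon with a double bond to nitrogen). For compound 3 a modest move back in the weaker direction is expected, a 2.2-fold higher number from compound 2 to compound 3 (0.35 log units; beyond the scatter), because a 3.1-fold lower number from compound 1 to compound 2 (0.49 log units; beyond the scatter) shows that such an aryl exchange shifts the number only modestly. Compound 3 is therefore estimated at 2000 nM, within 700 nM to 6000 nM.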

Compound 3, half-maximal inhibitory concentration: 520 nM
Compound 3: the middle estimate sits 3.8-fold (0.59 log units) above what was measured; the measured number lies below the stated range.
By their numbers in this assay, from the lowest: compounds 3 and 2 (each within the scatter of the next); then compound 1.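

In this assay, the step of a 1.7-fold lower number from compound 2 to compound 3 (0.23 log units; within the scatter) shows that the second aromatic ring and the hydrogen-bond donor and acceptor leaving with 2-hydroxynaphthalen-1-yl are not needed to keep the number at this level on the carbon with a double bond to nitrogen. A much smaller group, 3-bromophenyl, also stands clear of 3,4,5-trimethoxyphenyl, with a 5.3-fold lower number from compound 1 to compound 3 (0.73 log units; beyond the scatter). Nothing available explains these numbers. The compounds shown leave open whether the bromine itself matters, as an unsubstituted phenyl would test, and how an aryl group carrying an amine or a carboxylic acid would fare here.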